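Trifluoromethoxy for Trifluoromethyl: A Small Step Expected

The source may report more compounds than this note shows. Statements on the series, on what has been measured and on what is new or still open speak of the compounds shown alone.

Of the compounds shown here, two have numbers so far in a physicochemical assay for lipophilicity, read by HPLC, with a stated time of 90 min, tested at 100 uM (on this read-out higher numbers stand for higher lipophilicity and lower numbers for lower lipophilicity), on record. Compound 1 (`O=C(Nc1ccc(OC(F)(F)F)cc1)NC1CCN(C(=O)C2CCOCC2)CC1`) gives 3.26 in this measurement, and compound 2 (`Cc1ccoc1C(=O)N1CCC(NC(=O)Nc2ccc(C(F)(F)F)cc2)CC1`) gives 4.29 in the same measurement. Compound 2 thus holds the higher of the two numbers, and the gap between them lies beyond the usual scatter. Compound 3 (`Cc1ccoc1C(=O)N1CCC(NC(=O)Nc2ccc(OC(F)(F)F)cc2)CC1`) has yet to be measured. It departs from compound 2 in one place, on an aromatic carbon of a six-membered aromatic ring of carbon only, para to a large group, where trifluoromethoxy stands in place of trifluoromethyl (trifluoromethoxy in place of trifluoromethyl on an aromatic carbon). Among the measured compounds shown here, no measured pair shows this exchange alone, so the expectation has no direct precedent. It starts from compound 2 at 4.29 and foresees only a small upward move in this assay that stays within the scatter. The expected change is a number 0.11 log units higher from compound 2 to compound 3 (within the scatter) on this scale. For compound 3 the estimated value is 4.4 in this measurement, with an expected range from 4.05 to 4.75 around it.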

Compound 3, partition coefficient: 4.48
Compound 3: middle estimate off by 0.08 log units, on the low side; low and high end bracket the measured number.
By their numbers in this assay, from the lowest: compound 1; then compounds 2 and 3 (each within the scatter of the next).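

In this assay, among the compounds shown here, the exchange of trifluoromethyl for trifluoromethoxy on an aromatic carbon of a six-membered aromatic ring of carbon only, para to a large group, gives a number 0.19 log units higher from compound 2 to compound 3 (within the scatter) and so offers the first direct reading at this position: here the two groups cannot be told apart by this measurement. For the compounds shown here, compound 3 also gives a first single-place comparison on the carbonyl carbon, where 3-methylfuran-2-yl in place of oxan-4-yl gives a number 1.22 log units higher from compound 1 to compound 3 (beyond the scatter) and thus, unlike the exchange on the aromatic carbon, moves the number well past the scatter. Nothing on record explains the size of either step.

As far as these compounds go, it remains open whether the exchange on the aromatic carbon would stay this small with oxan-4-yl rather than 3-methylfuran-2-yl on the carbonyl carbon, since a single pair with one partner at that site cannot show it. Also open, from the compounds shown here alone, is how this assay would respond to an amine or a carboxylic acid on the aromatic carbon, or to a longer chain on the carbonyl carbon.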